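Methoxyphenyl Replaces Chlorophenyl on a Shared Imidazopyrazine Core

A few compounds are considered here, and "the series" means these few. Any claim that something is new, unique, unknown or untested is made for them only; others in the source may bear on it.

Measured so far:
Compound 1 `Fc1ccc(-c2cn3ccnc3c(-c3ccc4ncn(C5CCCCC5)c4c3)n2)cc1`: 2.03%
Compound 2 `Clc1ccc(-c2cn3ccnc3c(-c3ccc4ncn(C5CCCCC5)c4c3)n2)cc1`: 15.6%

Of the compounds shown here, two have been tested in a functional assay on HL-60 cells (Homo sapiens) for inhibition, read by sulforhodamine B assay, with a stated time of 48 h, tested at 10 uM; on this read-out lower numbers stand for less inhibition and higher numbers for more inhibition at the one concentration tested (going by the name of the read-out). Compound 1 `Fc1ccc(-c2cn3ccnc3c(-c3ccc4ncn(C5CCCCC5)c4c3)n2)cc1` gives 2.03% in this assay, and compound 2 `Clc1ccc(-c2cn3ccnc3c(-c3ccc4ncn(C5CCCCC5)c4c3)n2)cc1` gives 15.6%. Among the measured compounds shown here, the one measured step between them, a number 13.6 percentage points higher from compound 1 to compound 2 (beyond the scatter), lies beyond the scatter. Compound 2 therefore stands highest of the two numbers, with compound 1 as its nearest neighbour by that same modest margin.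

Compound 3 `COc1ccccc1-c1cn2ccnc2c(-c2ccc3ncn(C4CCCCC4)c3c2)n1` differs from compound 2 by 2-methoxyphenyl in place of 4-chlorophenyl on an aromatic carbon. For the measured compounds named here, the only measured step, chloro in place of fluoro on an aromatic carbon, does not bear on this change, since here the whole 4-chlorophenyl group leaves and a 2-methoxyphenyl group enters. Going by the values given here, no measured step therefore anchors the direction, and the expectation rests on the two values alone, which span a modest range. Compound 3 is estimated to show a step of a number 5.6 percentage points lower from compound 2 to compound 3 (within the scatter) in this assay, with no firm direction beyond the scatter. Compound 3 is expected at 10%, in a range from 0% to 30%.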

Compound 3, a percentage reported as inhibition, at one concentration (the size of the read-out at that concentration, not a potency): 14.6%
For compound 3 the middle estimate is 4.6 percentage points below the measured one; the measured number falls inside the stated range.
By their numbers in this assay, from the lowest: compound 1; then compounds 3 and 2 (each within the scatter of the next).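

In this assay, the exchange of 4-chlorophenyl for 2-methoxyphenyl gives a number 1 percentage points lower from compound 2 to compound 3 (within the scatter), so two groups that differ in their substituent and in where it sits on the phenyl ring give numbers that cannot be told apart at this position. Set against the 4-fluorophenyl group, the same 2-methoxyphenyl group gives a number 12.6 percentage points higher from compound 1 to compound 3 (beyond the scatter), which means that compound 1 now stands apart from both other compounds, whereas before it was set against compound 2 alone. Among these three compounds, the 4-fluorophenyl group is thus the one change at this position that separates from the others beyond the scatter, and no measurement at hand explains this result.

The compounds shown cannot separate the effect of exchanging chloro for methoxy from the effect of moving the substituent on the phenyl ring, as compound 3 changes both at once. They also leave open whether a group of another kind at this position, such as an amine or a carboxylic acid on the phenyl ring, would give a number clearly beyond those of compound 2 and compound 3.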